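Swapping 2-aminophenyl for pyridin-3-yl in compound 1

A few compounds are considered here, and "the series" means these few. Any claim that something is new, unique, unknown or untested is made for them only; others in the source may bear on it.

In an ADME assay on BJ cells (Homo sapiens) for cytotoxicity, with a stated time of 72 h (on this read-out higher numbers stand for an effect only at larger amounts of compound and lower numbers for an effect already at smaller amounts), compound 1 (`Cc1cc(NC(=O)Nc2ccccc2N)c2ccccc2n1`) gives > 25000 nM as its reading, and this is a limit of the assay, not a number. Compound 3 (`Cc1cc(NC(=O)Nc2cccnc2)c2ccccc2n1`) carries pyridin-3-yl in place of 2-aminophenyl on an amide-type nitrogen. Going by the values given here, only one measured step bears on this change: tert-butyl in place of amino on an aromatic carbon leads to compound 2 (`Cc1cc(NC(=O)Nc2ccccc2C(C)(C)C)c2ccccc2n1`). In this assay compound 2 gives 22000 nM as a true number. That step is small (an at least 1.1-fold lower number from compound 1 to compound 2 (0.05 log units; that floor lies within the scatter)). Among the compounds with values here, it is also the only guide, so the swap in compound 3 is expected to make no difference beyond the scatter, and no direction can be given. The expected step is slight (an at least 1.0-fold lower number from compound 1 to compound 3 (0.01 log units; that floor lies within the scatter)). Compound 3 is estimated at 24000 nM (expected range 11000 nM to 50000 nM).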

Compound 3, half-maximal effective concentration: > 25000 nM
Compound 3 was reported as a limit (the forecaster's own chance of this, stated with the estimate: 65%); middle value at least 1.0-fold (0.01 log units) from the limit.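

Going by these compounds alone, compound 1 and compound 3 both read as a limit of the assay rather than a number, so no step between them can be read: the limit of > 25000 nM in this assay, at which 2 of the 3 values shown sit. The compounds shown leave open whether pyridin-3-yl in place of 2-aminophenyl changes the reading in this assay at all.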